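The source may hold more compounds than are shown below. What is called first, only, known or untested is meant among the compounds shown, and "the series" means these compounds.

Measured so far in a functional assay on KYSE-70 cells for antiproliferative activity against KYSE-70 cell line (Homo sapiens), read by MTT assay, with a stated time of 72 h; a higher number here means a weaker inhibitor, a lower number a stronger inhibitor:
- Compound 1 `O=C(Nc1cc(F)cc(F)c1)c1cc(=O)[nH]c2cc(Br)ccc12`: 10700 nM
- Compound 2 `O=C(Nc1cc(F)cc(F)c1)c1cc(=O)[nH]c2cc(F)ccc12`: > 20000 nM, which is a limit and not a number
- Compound 3 `O=C(Nc1cccc(F)c1)c1cc(=O)[nH]c2cc(-c3ccc(F)cc3)ccc12`: 3300 nM

Compound 3, at 3300 nM, has the lower of the two actual numbers in the series. The gap to compound 1 at 10700 nM lies beyond the scatter.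

Compound 4 `Cc1ccc(-c2ccc3c(C(=O)Nc4cccc(F)c4)cc(=O)[nH]c3c2)cc1` is the next compound to consider. It differs from compound 3 by one change, 4-fluorophenyl to 4-methylphenyl: methyl in place of fluoro on an aromatic carbon. The methyl takes the place of the fluoro on an aromatic carbon, para to a large group.

Among the compounds with values here, only one measured step is available: an at least 1.8-fold higher number from compound 1 to compound 2 (0.27 log units; that floor lies within the scatter). That step is a halogen exchange on the shared core, and its size is only a floor, set by the limit of > 20000 nM in this assay, at which 1 of the 3 values shown sits. Within the data shown here, no measured step brings in a methyl or alters the 4-fluorophenyl group, so the series gives no direct guide to this change.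

In this assay, no step beyond the scatter is therefore expected, and neither direction is favoured. The expectation rests on compound 3 at 3300 nM.

The expected step is a 1.1-fold higher number from compound 3 to compound 4 (0.03 log units; within the scatter).

The estimate for compound 4 is 3500 nM, with an expected range of 1500 nM to 8500 nM.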

Compound 4, half-maximal inhibitory concentration: > 20000 nM
Compound 4 gave a limit, no number; the forecaster's own chance of this, stated with the estimate: 5%; at least 5.7-fold (0.75 log units) between middle value and limit.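

In this assay, the change from 4-fluorophenyl to 4-methylphenyl gives an at least 6.0-fold higher number from compound 3 to compound 4 (0.78 log units; beyond the scatter), so exchanging one heavy atom for another at this position is not neutral. The only earlier step was a halogen exchange on the shared core with a floor inside the scatter, which makes this the first single change in the series shown to lie beyond it. Compound 4 gives > 20000 nM, which is a limit and not a number, so the size of the step is only a floor: the limit of > 20000 nM in this assay, at which 2 of the 4 values shown sit.

As far as these compounds go, it remains open whether this drop is particular to the methyl or extends to other replacements for the fluoro, such as a chloro, a methoxy, an amine or a carboxylic acid at the same place. Also open, from the compounds shown here alone, are how far compound 4 lies past its limit and whether the same change reads alike when the amide group of compound 1 is carried in place of that of compound 3.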